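The source may hold more compounds than are shown below. What is called first, only, known or untested is meant among the compounds shown, and "the series" means these compounds.

Measured so far:
compound 1 `O=S(=O)(Nc1ncc(C(Oc2ccc3cc(Br)ccc3c2)c2ccc(Cl)cc2)s1)c1ccccc1` — > 50000 nM
compound 2 `O=S(=O)(Nc1ncc(C(Oc2ccc3cc(Br)ccc3c2)c2ccc(Cl)cc2)s1)c1cccc2nsnc12` — "not toxic" (no number reported)

In an ADME assay on HepG2 2.2.15 cells (Homo sapiens) for cytotoxicity (on this read-out lower numbers stand for higher toxicity in this test and higher numbers for lower toxicity in this test), compound 1 gives only a limit of the assay, > 50000 nM. Compound 2 stands in this assay without a number, reported simply as "not toxic" (no number reported). Compound 3 `O=S(=O)(Nc1ncc(C(Oc2ccc3cc(Br)ccc3c2)c2ccc(Cl)cc2)s1)c1cccc2cccnc12` differs from compound 2 by a group of 10 heavy atoms (9 carbon, 1 nitrogen; one six-membered aromatic ring of carbon only, one six-membered aromatic ring with 1 hetero atom) in place of a group of 9 heavy atoms (6 carbon, 2 nitrogen, 1 sulfur; one five-membered aromatic ring with 3 hetero atoms, one six-membered aromatic ring of carbon only), on a sulfonyl sulfur. For the measured compounds named here, no measured step of this kind is available, so no shift beyond the scatter is expected in this assay from this change. Compound 3 is therefore expected at 50000 nM, within a range of 20000 nM to 100000 nM, most likely again reported as a limit.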

Compound 3, half-maximal cytotoxic concentration: > 50000 nM
Compound 3 was reported as a limit (the forecaster's own chance of this, stated with the estimate: 70%); the middle value lies on the limit itself.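

No step can be read between compound 1, compound 2 and compound 3 in this assay, because none of them carries a plain number: the limit of > 50000 nM in this assay, at which 2 of the 3 values shown sit.

The compounds shown leave open at what concentration, if any, these compounds harm the cells.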